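A few compounds are considered here, and "the series" means these few. Any claim that something is new, unique, unknown or untested is made for them only; others in the source may bear on it.

Measured compounds:
Compound 1, `CC(C)(Oc1ccccc1)C1OCC(C/C=C\CCC(=O)O)C(c2cccnc2)O1`, gives 75.9 nM in a functional assay for inhibition, with Homo sapiens as the target; a lower number here means tighter binding, a higher number weaker binding.
Compound 2, `CC(C)(Oc1ccccc1F)C1OCC(C/C=C\CCC(=O)O)C(c2cccnc2)O1`, gives 166 nM in this assay.
Compound 3, `CC(C)(Cc1ccccc1)C1OCC(C/C=C\CCC(=O)O)C(c2cccnc2)O1`, gives 513 nM in this assay.

The change from compound 1 to compound 2 is fluoro in place of hydrogen on an aromatic carbon, and it moved the number by a 2.2-fold higher number from compound 1 to compound 2 (0.34 log units; beyond the scatter). The two cores differ as described in benzyl in place of phenoxy on a saturated chain carbon bound to two saturated chain carbons and a saturated ring carbon, a change that carried a 6.8-fold higher number from compound 1 to compound 3 (0.83 log units; beyond the scatter); compound 2 and compound 3 are separated by a 3.1-fold higher number from compound 2 to compound 3 (0.49 log units; beyond the scatter).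

Compound 4, `CC(C)(Cc1ccc(F)cc1)C1OCC(C/C=C\CCC(=O)O)C(c2cccnc2)O1`, has not yet been measured. It differs from compound 3 by fluoro in place of hydrogen on an aromatic carbon. This is the same kind of change as that from compound 1 to compound 2, but not the same: in compound 2 the fluoro stands ortho to a large group on a phenoxy, whereas in compound 4 it stands para to a large group on a benzyl, and the cores carrying the two rings differ as stated above.

For the measured compounds named here, with only one measured instance of this kind of change, the expectation for compound 4 rests on compound 1 and compound 2, whose step was a 2.2-fold higher number from compound 1 to compound 2 (0.34 log units; beyond the scatter); a step of similar size is expected, a 1.9-fold higher number from compound 3 to compound 4 (0.27 log units; within the scatter), with added uncertainty because the place and core differ. Compound 4 is therefore estimated at 950 nM in this assay, expected to fall between 400 nM and 2300 nM.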

Compound 4, dissociation constant: 89.1 nM
Beside the measured number, compound 4's estimate is 11-fold (1.03 log units) above it, outside the stated range (below it).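

In this assay, fluoro in place of hydrogen on an aromatic carbon did not carry over from one core to the other, and the two steps run in opposite directions: the same change on two cores in this assay, a 2.2-fold higher number (0.34 log units; beyond the scatter) from compound 1 to compound 2 and a 5.8-fold lower number (0.76 log units; beyond the scatter) from compound 3 to compound 4, 13-fold (1.10 log units) apart, beyond the scatter of two such steps

On the benzyl side the change gave a 5.8-fold lower number from compound 3 to compound 4 (0.76 log units; beyond the scatter), and it left the 4-fluorobenzyl compound level with both phenoxy compounds, at a 1.2-fold higher number from compound 1 to compound 4 (0.07 log units; within the scatter) and a 1.9-fold lower number from compound 2 to compound 4 (0.27 log units; within the scatter), so the gap seen between the phenoxy and benzyl series without fluoro does not persist once this fluoro is present. What this does not show is why the steps differ: the two pairs differ both in the core and in where the fluoro stands on the ring, and with one pair of each kind the data cannot separate these two differences, nor do they show that any fluoro on a benzyl ring would behave as this one does.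

A 4-fluorophenoxy group on the core of compound 1 and a 2-fluorobenzyl group on the core of compound 3 would tell place from core, and neither is among the compounds shown. From the compounds shown here alone, whether chloro or methyl at the same place on the benzyl ring would give a similar step also remains open.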